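The compounds below may be only part of what the source reports. "The series", "measured", "known", "first", "only" and "open" are said of these compounds alone.

Measured compounds:
compound 1 `N#Cc1ccc(Nc2nccc(Oc3ccc(-c4ccc(C#N)cc4)c(F)c3)n2)cc1`: in a functional assay on MT4 cells (Homo sapiens) for cytotoxicity, read by MTT assay, with a stated time of 5 days (on this read-out higher numbers stand for lower toxicity in this test and lower numbers for higher toxicity in this test), compound 1 gives > 307000 nM, a limit of the assay.
compound 2 `COc1cc(Nc2ccnc(Nc3ccc(C#N)cc3)n2)ccc1-c1ccc(C#N)cc1`: in this assay compound 2 gives 5260 nM.
compound 3 `COc1cc(Oc2ccnc(Nc3ccc(C#N)cc3)n2)ccc1-c1ccc(C#N)cc1`: in this assay compound 3 gives > 298000 nM, a limit of the assay.

Compound 2 is the only one of the three with a number; the other two values are limits. The change from compound 3 to compound 1 is fluoro in place of methoxy on an aromatic carbon. Its step that the two limits leave unreadable from compound 3 to compound 1 has no readable size, because the limit of > 307000 nM in this assay, at which 1 of the 3 values shown sits, and the limit of > 298000 nM in this assay, at which 1 of the 3 values shown sits, are its two ends.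

Compound 4 `N#Cc1ccc(Nc2nccc(Nc3ccc(-c4ccc(C#N)cc4)c(F)c3)n2)cc1` is not yet measured in this assay. The change from compound 2 to compound 4 is fluoro in place of methoxy on an aromatic carbon, the same change as from compound 3 to compound 1, at the same kind of place. How the core of compound 2 and the core of compound 3 differ is not broken down here.

Among the compounds with values here, the one measured instance of this change gives no size, because a step that the two limits leave unreadable from compound 3 to compound 1 sits between two limits. The expectation for compound 4 therefore rests on compound 2 and its value 5260 nM, with a wide band. The estimated step is a 1.5-fold higher number from compound 2 to compound 4 (0.18 log units; within the scatter). Compound 4 is expected at 8000 nM, between 2500 nM and 40000 nM.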

Compound 4, half-maximal cytotoxic concentration: > 271000 nM
Compound 4: a limit, no number; the forecaster's own chance of this, stated with the estimate: 15%; middle value at least 33-fold (1.52 log units) from the limit.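

Fluoro in place of methoxy, ortho to a 4-cyanophenyl group, gives an at least 51-fold higher number from compound 2 to compound 4 (1.71 log units; beyond the scatter), so on the core of compound 2 this change goes with a large move towards lower toxicity in this assay. On the core of compound 3 the same change cannot be read, since compound 3 and compound 1 both stand at limits of the assay, and so no size can be set beside the one seen here and nothing shows that the change acts alike on both cores. The readable step also has a limit at one end, and it rests on a single pair, which supports no rule for the series.

It stays open whether the shift belongs to fluoro itself or to the loss of methoxy, as the compounds shown hold neither hydrogen nor chloro at this place. On these data alone, how an amine such as dimethylamino or a longer chain such as propoxy would read there in this assay also stays open.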